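Hydroxy for azido on a selenium sugar ring

This account rests on a few compounds, and the source may have more. Where it says the series, first, only, none or still open, it means among the compounds named here.

Measured compounds:
compound 1, `Cc1cn(C2[Se][C@H](CO)[C@@H](O)[C@@H]2N=[N+]=[N-])c(=O)[nH]c1=O`: > 100000 nM
compound 2, `[N-]=[N+]=N[C@@H]1C(n2cc(I)c(=O)[nH]c2=O)[Se][C@H](CO)[C@H]1O`: > 100000 nM

In a functional assay on PC-3 cells (Homo sapiens) for cytotoxicity, read by sulforhodamine B assay (a higher number here means a weaker inhibitor, a lower number a stronger inhibitor), compound 1 gives > 100000 nM, which is a limit of the assay and not a number. Compound 2 gives > 100000 nM in this assay, again a limit. Going by the values given here, the one measured step, a step that the two limits leave unreadable from compound 1 to compound 2, is therefore not readable, and compound 1 stands only at a limit; both values shown sit at the same edge of the assay, as the limit of > 100000 nM in this assay, at which 2 of the 2 values shown sit, states.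

Compound 3, `Cc1cn(C2[Se][C@H](CO)[C@@H](O)[C@@H]2O)c(=O)[nH]c1=O`, differs from compound 1 by hydroxy in place of azido on a saturated ring carbon. Among the compounds with values here, no measured step bears on this exchange; the only step in hand alters the aromatic substituent and shows nothing, since both of its ends are limits. What is known of compound 1 is its limit in this assay, and nothing in the data points to a change in either direction for compound 3. Compound 3 is therefore expected to reach about 100000 nM in this assay, within a range from 20000 nM to 300000 nM. The step from compound 1 to compound 3 is estimated as a number no higher from compound 1 to compound 3 (the limit leaves the size open), most likely leaving compound 3 at the limit as well.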

Compound 3, half-maximal inhibitory concentration: > 100000 nM
Compound 3: only a limit was reported; the forecaster's own chance of this, stated with the estimate: 80%; the middle value sits exactly at the limit.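

In this assay compound 3 gives > 100000 nM, which is a limit and not a number. Compound 1 also stands at a limit, so no step can be read between compound 1 and compound 3. The compounds shown leave open how compound 1, compound 2 and compound 3 compare, as all stand at one edge of the assay: the limit of > 100000 nM in this assay, at which 3 of the 3 values shown sit.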